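Replacing the methoxyphenyl amide in a chromone series

The compounds below may be only part of what the source reports. "The series", "measured", "known", "first", "only" and "open" are said of these compounds alone.

Three measured compounds share a core and differ in the group on one amide carbonyl carbon. In an assay on isolated protein for inhibition of Rho-associated protein kinase 1 (Homo sapiens), read by scintillation counting, radiometric assay and 33P incorporation, with a stated time of 40 min, in the presence of a further agent that is not named here (on this read-out lower numbers stand for stronger inhibition and higher numbers for weaker inhibition), compound 1 `CC(=O)Nc1cccc(NC(=O)COc2ccc3c(=O)ccoc3c2)c1` gives 2500 nM, compound 2 `O=C(COc1ccc2c(=O)ccoc2c1)Nc1cccc(NC(=O)c2ccccc2)c1` gives 120 nM, and compound 3 `COc1ccc(C(=O)Nc2cccc(NC(=O)COc3ccc4c(=O)ccoc4c3)c2)cc1` gives 18 nM. Compound 3 holds the lowest number of the three: the step of a 6.7-fold lower number from compound 2 to compound 3 (0.82 log units; beyond the scatter) is beyond the scatter, and the step of a 140-fold lower number from compound 1 to compound 3 (2.14 log units; beyond the scatter) is larger still. The step of a 21-fold lower number from compound 1 to compound 2 (1.32 log units; beyond the scatter) shows that an aromatic ring on that carbonyl carbon, in place of methyl, already brings most of the gain.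

Compound 4 `CC(C)(C)c1cc(C(=O)Nc2cccc(NC(=O)COc3ccc4c(=O)ccoc4c3)c2)no1` carries the change (5-(tert-butyl)-1,2-oxazol-3-yl in place of 4-methoxyphenyl on a carbonyl carbon). Going by the values given here, no measured step swaps one aromatic group for another here; the measured steps only show that an aromatic ring is favoured over methyl and that methoxy on that ring helps. From the compounds shown here alone, because the methoxy contribution seen in a 6.7-fold lower number from compound 2 to compound 3 (0.82 log units; beyond the scatter) is given up, and the new ring is untested, a modest rise in number is expected for compound 4, as a 2.8-fold higher number from compound 3 to compound 4 (0.44 log units; beyond the scatter). In this assay compound 4 is expected to give about 50 nM, between 12 nM and 250 nM.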

Compound 4, half-maximal inhibitory concentration: 101 nM
For compound 4 the middle estimate is 2.0-fold (0.31 log units) below the measured one; measured number inside the range.
By their numbers in this assay, from the lowest: compound 3; then compounds 4 and 2 (each within the scatter of the next); then compound 1.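

At this carbonyl carbon, the aromatic ring need not be a six-membered ring of carbon only: in this assay, the five-membered 5-(tert-butyl)-1,2-oxazol-3-yl group still gives a 25-fold lower number from compound 1 to compound 4 (1.39 log units; beyond the scatter). Set against plain phenyl, it shows a 1.2-fold lower number from compound 2 to compound 4 (0.07 log units; within the scatter), so these two groups cannot be told apart, while replacing 4-methoxyphenyl gives a 5.6-fold higher number from compound 3 to compound 4 (0.75 log units; beyond the scatter). No evidence at hand accounts for these differences.

The compounds shown leave open how much of the value of compound 4 belongs to the tert-butyl group and how much to the ring, which a methyl in place of tert-butyl on the same ring would help to separate. They also leave open how a pyridine ring or a 4-aminophenyl group would fare on this carbonyl carbon.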